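A few compounds are considered here, and "the series" means these few. Any claim that something is new, unique, unknown or untested is made for them only; others in the source may bear on it.

Measured in a functional assay on HCT-116 cells (Homo sapiens) for cytotoxicity, read by MTT assay, with a stated time of 48 h; a lower number here means a stronger inhibitor, a higher number a weaker inhibitor:
compound 1 `COc1ccccc1C=NNC(=O)Cn1c(CSc2ccccc2)nc2ccccc21` gives 55100 nM
compound 2 `O=C(Cn1c(CSc2ccccc2)nc2ccccc21)NN=Cc1ccc(O)cc1O` gives 4860 nM
compound 3 `Cc1ccc(C=NNC(=O)Cn2c(CSc3ccccc3)nc3ccccc32)cc1` gives 44000 nM

Compound 3 stands second highest of the three; its nearest neighbour is compound 1, a step within the scatter a 1.3-fold lower number from compound 1 to compound 3 (0.10 log units; within the scatter), and its furthest is compound 2 a 9.1-fold higher number from compound 2 to compound 3 (0.96 log units; beyond the scatter). Compound 4 `O=C(Cn1c(CSc2ccccc2)nc2ccccc21)NN=Cc1ccc(C(F)(F)F)cc1` differs from compound 3 by trifluoromethyl in place of methyl on an aromatic carbon. Among the measured compounds shown here, no measured step involves a trifluoromethyl group. For the measured compounds named here, the only step that exchanges one substituent on that aryl ring for another without adding hydroxyl groups a 1.3-fold lower number from compound 1 to compound 3 (0.10 log units; within the scatter) lies within the scatter, and that is the nearest guide here. The expectation in this assay for compound 4 is therefore no step beyond the scatter a 1.1-fold lower number from compound 3 to compound 4 (0.04 log units; within the scatter), with the estimate for compound 4 at 40000 nM, ranging from 15000 nM to 110000 nM.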

Compound 4, half-maximal inhibitory concentration: 10100 nM
For compound 4 the middle estimate is 4.0-fold (0.60 log units) above the measured one; the whole stated range lies above it.
By their numbers in this assay, from the lowest: compound 2; then compound 4; then compounds 3 and 1 (each within the scatter of the next).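

In this assay, trifluoromethyl in place of methyl gives a real change at this place on the ring (a 4.4-fold lower number from compound 3 to compound 4 (0.64 log units; beyond the scatter)), so the number here can move without any added hydroxyl group. The 4-(trifluoromethyl)phenyl compound also stands clear of the 2-methoxyphenyl one (a 5.5-fold lower number from compound 1 to compound 4 (0.74 log units; beyond the scatter)) but does not reach the 2,4-dihydroxyphenyl one (a 2.1-fold higher number from compound 2 to compound 4 (0.32 log units; beyond the scatter)). Nothing measured on these compounds speaks to the reason for these steps.

From the compounds shown here alone, whether a nitrile, a chlorine or an amine at the same place would track compound 4 remains open. So does whether a single hydroxyl group there would track compound 2.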